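A few compounds are considered here, and "the series" means these few. Any claim that something is new, unique, unknown or untested is made for them only; others in the source may bear on it.

Of the compounds shown here, two have so far been measured, both on the same shared core. Compound 1 `Cn1cnc2c(Sc3ccc(F)cc3)ncnc21` gives 5% in an assay on isolated protein for inhibition of Ca2+/calmodulin-dependent protein kinase II (CaM kinase II) (Rattus norvegicus), tested at 30 uM; on this read-out lower numbers stand for less inhibition and higher numbers for more inhibition at the one concentration tested (going by the name of the read-out). Compound 2 `CSc1ccc(-c2nc3c(Sc4ccc(F)cc4)ncnc3n2C)cc1`, which carries a 4-(methylsulfanyl)phenyl in place of hydrogen on an aromatic carbon, gives 7% in this assay. Among the compounds with values here, the single step between them is a number 2 percentage points higher from compound 1 to compound 2 (within the scatter), so the two numbers cannot be told apart. Compound 2 stands highest of the two numbers shown, with compound 1 nearest, a number within the scatter below it.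

Compound 3 `Cn1c(-c2ccc(S(C)(=O)=O)cc2)nc2c(Sc3ccc(F)cc3)ncnc21` differs from compound 2 in one place: methylsulfonyl in place of methylsulfanyl on an aromatic carbon. Within the data shown here, no measured step changes this group, so the only step that bears on compound 3 is the one from compound 1 to compound 2, which stayed within the scatter. Among the measured compounds shown here, with both measured numbers low and no step of size anywhere in the data, the step of a number 1 percentage points higher from compound 2 to compound 3 (within the scatter) is expected to stay within the scatter. Compound 3 is therefore estimated to give 8% in this assay, with a plausible range from -5% to 22%.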

Compound 3, a percentage reported as inhibition, at one concentration (the size of the read-out at that concentration, not a potency): 0%
Compound 3: the middle estimate sits 8 percentage points above what was measured; low and high end bracket the measured number.
By their numbers in this assay, from the lowest: compounds 3, 1 and 2 (each within the scatter of the next).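

In this assay, the change at this position, on the aromatic carbon para to a large group, gives a number 7 percentage points lower from compound 2 to compound 3 (within the scatter). The entering methylsulfonyl has 4 heavy atoms and 2 hydrogen-bond acceptors, against 2 heavy atoms and 1 hydrogen-bond acceptor for methylsulfanyl, yet this difference in the group does not produce a step that can be told apart from the scatter, so the read-out does not separate these two sulfur groups. No measurement at hand offers an explanation for this result.

Both steps shown, including a number 2 percentage points higher from compound 1 to compound 2 (within the scatter), stay within the scatter at the one concentration tested, so the data do not reveal whether any substituent on this six-membered aromatic ring can move the read-out by a clear margin. From the compounds shown here alone, it remains open whether an amine or a carboxylic acid in this same place, in place of the sulfur-containing group, would give a number beyond the scatter from compound 2.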